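Moving the methyl on the amide-bound aryl ring

The source may report more compounds than this note shows. Statements on the series, on what has been measured and on what is new or still open speak of the compounds shown alone.

Among the compounds with values here, compound 2 `Cc1cc(CC(=O)O)cc(NC(=O)c2ccc(OC[C@@H]3CN(C)c4ccccc4O3)cc2Cl)c1` gives 12 nM in an assay on CHO cells for displacement of a labelled ligand from prostaglandin D2 receptor (Mus musculus), read by scintillation counting, with a stated time of 60 min (a lower number here means a stronger inhibitor, a higher number a weaker inhibitor), the lowest of the two numbers so far; compound 1 `Cc1ccc(CC(=O)O)cc1NC(=O)c1ccc(OC[C@@H]2CN(C)c3ccccc3O2)cc1Cl` gives 26 nM. Compound 3 `Cc1ccc(NC(=O)c2ccc(OC[C@@H]3CN(C)c4ccccc4O3)cc2Cl)cc1CC(=O)O` differs from compound 2 only in 3-(carboxymethyl)-4-methylphenyl in place of 3-(carboxymethyl)-5-methylphenyl on an amide-type nitrogen. Within the data shown here, the one step that bears on this, a 2.2-fold lower number from compound 1 to compound 2 (0.34 log units; beyond the scatter), also shifted the methyl on that ring and was modest. A step of similar size, in either direction, is therefore expected for compound 3, a 1.7-fold higher number from compound 2 to compound 3 (0.22 log units; within the scatter). Compound 3 is estimated at 20 nM, within a range of 8 nM to 50 nM.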

Compound 3, inhibition constant: 17 nM
For compound 3 the middle estimate is 1.2-fold (0.07 log units) above the measured one; measured number inside the range.
By their numbers in this assay, from the lowest: compounds 2, 3 and 1 (each within the scatter of the next, the first and the last beyond it).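

In this assay, 3-(carboxymethyl)-4-methylphenyl on the amide-type nitrogen cannot be separated from either earlier isomer: a 1.4-fold higher number from compound 2 to compound 3 (0.15 log units; within the scatter) and a 1.5-fold lower number from compound 1 to compound 3 (0.18 log units; within the scatter) both lie within the scatter. Of the three arrangements on this ring, only compound 1 and compound 2 stand apart beyond the scatter, so these same-atom rearrangements have so far produced only modest steps.

Still open, as far as these compounds go, is whether methoxy in place of the methyl, or a longer chain in place of carboxymethyl, would give a larger step. No evidence accounts for these numbers.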